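Replacing pyridin-4-yl with 4-bromophenyl on an amide-type nitrogen

The source may report more compounds than this note shows. Statements on the series, on what has been measured and on what is new or still open speak of the compounds shown alone.

Values measured in a functional assay on HCT-116 cells (Homo sapiens) for inhibition, read by colorimetric assay, with a stated time of 3 days; on this read-out lower numbers stand for stronger inhibition and higher numbers for weaker inhibition:

Compound 1 `O=C(CCCCCCCNC(=O)c1cc(=O)c(O)co1)Nc1ccccc1`: > 100000 nM (a limit of the assay, not a number)
Compound 2 `O=C(CCCCCCNC(=O)C(O)(O)C(F)(F)F)Nc1ccncc1`: 6670 nM
Compound 3 `CCOc1ccc(-c2cnc(NC(=O)CCCCCCNC(=O)C(O)(O)C(F)(F)F)s2)cc1`: 4050 nM

The value for compound 1 is a limit, so it gives no number to compare. That leaves two numbers in this assay. Compound 2 stands at 6670 nM and compound 3 at 4050 nM, and these two values lie within the scatter of each other, so neither can be ranked over the other.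

The next compound to be tested is compound 4 `O=C(CCCCCCNC(=O)C(O)(O)C(F)(F)F)Nc1ccc(Br)cc1`, which has not yet been measured. It differs from compound 2 in one place, with 4-bromophenyl in place of pyridin-4-yl on an amide-type nitrogen. Among the measured compounds shown here, no measured pair in this set isolates that change, so the only guide is the narrow spread of the two numbers already in hand, 6670 nM for compound 2 and 4050 nM for compound 3. A small move toward a lower number is therefore expected, probably not beyond the scatter. The expected change is a 1.9-fold lower number from compound 2 to compound 4 (0.28 log units; within the scatter). For compound 4 the estimated value is 3500 nM, with an expected range from 1200 nM to 10000 nM.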

Compound 4, half-maximal inhibitory concentration: 3130 nM
For compound 4 the middle estimate is 1.1-fold (0.05 log units) above the measured one, within the range that was stated.
By their numbers in this assay, from the lowest: compounds 4, 3 and 2 (each within the scatter of the next, the first and the last beyond it). At a limit, above all of these: compound 1.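

In this assay, among the compounds shown here, replacing pyridin-4-yl with 4-bromophenyl on the amide-type nitrogen gives the first step in this set that isolates a single place, a 2.1-fold lower number from compound 2 to compound 4 (0.33 log units; beyond the scatter), a modest change that lies beyond the scatter. For the compounds shown here, it shows that the number responds to the ring on this nitrogen while the rest of the structure stays the same, something the earlier compounds could not show, as no two of them differed in one place only. The change removes a ring with one hetero atom and one hydrogen-bond acceptor and brings in a carbon-only ring carrying bromine, and nothing measured here accounts for the step or assigns it to either part of that exchange.

On these data alone, whether the step comes from losing the ring nitrogen or from gaining the bromine stays open, and a plain phenyl on the same nitrogen, with the chain and the other end kept, would separate the two. Also open, as far as these compounds go, is whether 4-chlorophenyl, 4-methoxyphenyl or 4-aminophenyl at this place would move the number further, and whether the step would hold on a longer chain.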